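Adding a 4-fluorophenyl to a benzoxazolone acid ceramidase inhibitor

The source may report more compounds than this note shows. Statements on the series, on what has been measured and on what is new or still open speak of the compounds shown alone.

Measured compounds:
compound 1 `O=C(NCCCCc1ccccc1)n1c(=O)oc2ccccc21`: 64 nM
compound 2 `O=C(NCCCCc1ccccc1)n1c(=O)oc2cccc(Br)c21`: no result reported

Among the measured compounds shown here, compound 1 is the only compound with a number here. In an assay on HEK293 cells for inhibition of acid ceramidase (Homo sapiens), with a stated time of 10 min (a lower number here means a stronger inhibitor, a higher number a weaker inhibitor), compound 1 gives 64 nM, and compound 2 has no result reported, so nothing can be said about how it compares. Compound 3 `O=C(NCCCCc1ccccc1)n1c(=O)oc2cc(-c3ccc(F)cc3)ccc21` differs from compound 1 in one place: 4-fluorophenyl in place of hydrogen on an aromatic carbon. For the measured compounds named here, no measured pair shows what such a change does in this assay, so only an expectation can be given. Compound 3 is expected to land close to compound 1, with a step of a 1.6-fold lower number from compound 1 to compound 3 (0.20 log units; within the scatter) that may lie within the usual scatter or slightly toward stronger inhibition. The estimate for compound 3 is 40 nM, expected between 10 nM and 160 nM.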

Compound 3, half-maximal inhibitory concentration: 79 nM
Beside the measured number, compound 3's estimate is 2.0-fold (0.30 log units) below it; the measured number falls inside the stated range.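

In this assay, putting 4-fluorophenyl in place of hydrogen gives a 1.2-fold higher number from compound 1 to compound 3 (0.09 log units; within the scatter). This aromatic carbon on the core of compound 1 can therefore carry a whole extra aromatic ring with no shift in inhibition that stands out from the scatter. No measurement at hand offers an explanation for this result.

From the compounds shown here alone, whether an amine or a carboxylic acid at this same position would be tolerated as well remains open. So does the effect of a plain phenyl, without its fluorine, here.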